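The compounds below may be only part of what the source reports. "The series", "measured", "known", "first", "only" and "open" are said of these compounds alone.

The measured compounds:

Compound 1, `Cc1occc1-c1nnc(SCC(=O)Nc2cccc(F)c2)n1Cc1ccco1`, gives 501 nM in a functional assay on CHO cells for antagonist activity at Orexin receptor type 2 (Homo sapiens), read by FLIPR and calcium flux; a lower number here means a stronger inhibitor, a higher number a weaker inhibitor.
Compound 2, `COc1ccc(NC(=O)CSc2nnc(-c3ccoc3C)n2Cc2ccco2)cc1`, gives 200 nM in this assay.

Compound 2 stands at the lower of the two numbers; its nearest neighbour is compound 1, and the step of a 2.5-fold lower number from compound 1 to compound 2 (0.40 log units; beyond the scatter) is a modest one, beyond the scatter. Compound 3, `CC(=O)c1ccc(NC(=O)CSc2nnc(-c3ccoc3C)n2Cc2ccco2)cc1`, differs from compound 2 by acetyl in place of methoxy on an aromatic carbon. Among the measured compounds shown here, no measured step exchanges one of these two groups for the other; the only step available, from compound 1 to compound 2, alters the aryl substituent on the amide-type nitrogen and shows that such a change can move the number modestly. Without a closer precedent, compound 3 is expected to land near compound 2, and the step of a 1.5-fold higher number from compound 2 to compound 3 (0.18 log units; within the scatter) is estimated to stay within or just beyond the scatter. Compound 3 is therefore estimated at 300 nM in this assay, with a range from 100 nM to 1000 nM.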

Compound 3, inhibition constant: 31.6 nM
Beside the measured number, compound 3's estimate is 9.5-fold (0.98 log units) above it; the measured number lies below the stated range.
By their numbers in this assay, from the lowest: compound 3; then compound 2; then compound 1.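

In this assay, acetyl in place of methoxy, para to a large group, gives a 6.3-fold lower number from compound 2 to compound 3 (0.80 log units; beyond the scatter), a wider step than a 2.5-fold lower number from compound 1 to compound 2 (0.40 log units; beyond the scatter), so this one place on the aromatic ring can move the number more than the earlier aryl change showed. The 4-acetylphenyl group in place of 3-fluorophenyl gives a 16-fold lower number from compound 1 to compound 3 (1.20 log units; beyond the scatter), the only step among these compounds printed as large, even though methoxy and acetyl have the same count of hydrogen-bond acceptors and neither carries a net charge. Nothing given here explains the gain in strength.

Going by these compounds, whether an amine, a carboxylic acid or a longer ketone chain at this place would keep, extend or lose that gain remains open. Also open, on these data alone, is whether acetyl would give a similar step at another place on the ring or with a different group elsewhere on the shared core.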